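The source may report more compounds than this note shows. Statements on the series, on what has been measured and on what is new or still open speak of the compounds shown alone.

Measured so far in a functional assay for inhibition, with Homo sapiens as the target; a lower number here means a stronger inhibitor, a higher number a weaker inhibitor:
Compound 1 `C=CCn1ncc2c(CC)ncn2c1=O` gives > 48000 nM, which is a limit of the assay and not a number.
Compound 2 `C=CCn1ncc2c(CCC)ncn2c1=O` gives > 48000 nM, again a limit.
Compound 3 `Cc1nc(C(C)C)n2c(O)nncc12` gives > 48000 nM, again a limit.

Compound 2 and compound 1 differ by hydrogen in place of methyl on a saturated chain carbon, two bonds along the chain from an aromatic carbon. The step that the two limits leave unreadable from compound 2 to compound 1 cannot be read, since both ends are limits. Compound 4 `CCc1nc(C)c2cnnc(O)n12` is yet to be measured and differs from compound 3 by hydrogen in place of methyl on a saturated chain carbon bound to an aromatic carbon and a saturated chain carbon. For the measured compounds named here, this is the same kind of change as the one from compound 2 to compound 1, not the same: here the carbon that loses the methyl is bound to an aromatic carbon and a saturated chain carbon, whereas in the earlier pair it sits two bonds along the chain from an aromatic carbon. How the core of compound 3 differs from that of compound 2 is not broken down here. What is known is the limit of > 48000 nM in this assay, at which 3 of the 3 values shown sit. On that ground, the step from compound 3 to compound 4 is expected to be a step that the limit leaves unreadable from compound 3 to compound 4, essentially unreadable like the earlier one. Compound 4 is therefore estimated to give 60000 nM in this assay, most likely reported only as a limit, with a plausible range from 8000 nM to 400000 nM.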

Compound 4, half-maximal inhibitory concentration: > 48000 nM
Compound 4: a limit, no number; the forecaster's own chance of this, stated with the estimate: 85%; the middle value is on the limit's open side.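

In this assay compound 4 gives > 48000 nM and this is a limit of the assay, not a number. Compound 3 also stands at a limit, so the change from isopropyl to ethyl between compound 3 and compound 4 yields no readable step. The compounds shown leave open how large any of these changes is, and what would move a value off the limit: the limit of > 48000 nM in this assay, at which 4 of the 4 values shown sit.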